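Benzyl Swap on a Weakly Active Amide Series

The source may report more compounds than this note shows. Statements on the series, on what has been measured and on what is new or still open speak of the compounds shown alone.

Compounds measured so far:
compound 1 `Cc1ccc(CN2CCc3ncn(COCc4ccccc4)c3/C(=C/c3ccccc3)C2=O)cc1` — 39100 nM
compound 2 `O=C1/C(=C\c2ccccc2)c2c(ncn2COCc2ccccc2)CCN1Cc1ccc(F)cc1` — 72900 nM
compound 3 `O=C1/C(=C\c2ccccc2)c2c(ncn2COCc2ccccc2)CCN1Cc1ccc(-c2ccccc2)cc1` — 81000 nM

In a functional assay on BGC-823 cells (Homo sapiens) for inhibition, read by MTT assay, with a stated time of 72 h (a lower number here means a stronger inhibitor, a higher number a weaker inhibitor), compound 3 gives the highest number of the three. Its nearest neighbour is compound 2, and the step of a 1.1-fold higher number from compound 2 to compound 3 (0.05 log units; within the scatter) lies within the scatter, so the two cannot be ordered. Against compound 1 the step of a 2.1-fold higher number from compound 1 to compound 3 (0.32 log units; beyond the scatter) is modest but beyond the scatter, and a 1.9-fold higher number from compound 1 to compound 2 (0.27 log units; within the scatter) falls within it.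

Compound 4 `Cc1ccccc1CN1CCc2ncn(COCc3ccccc3)c2/C(=C/c2ccccc2)C1=O` differs from compound 3 in one place: 2-methylphenyl in place of 4-phenylphenyl on a saturated chain carbon bound to an amide-type nitrogen in a ring. Going by the values given here, of the measured steps, a 2.1-fold higher number from compound 1 to compound 3 (0.32 log units; beyond the scatter) bears most directly on this change, since it too exchanges methyl and phenyl on the aromatic carbon, though there the methyl sat in a different arrangement on the ring, and no measured pair covers the 2-methylphenyl group itself. Reversing that modest step suggests a somewhat lower number for compound 4 than for compound 3, but with little margin beyond the scatter. Compound 4 is therefore expected to give 45000 nM (range 20000 nM to 100000 nM), a step of a 1.8-fold lower number from compound 3 to compound 4 (0.26 log units; within the scatter).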

Compound 4, half-maximal inhibitory concentration: 31300 nM
Compound 4: the middle estimate sits 1.4-fold (0.16 log units) above what was measured, within the range that was stated.
By their numbers in this assay, from the lowest: compounds 4, 1, 2 and 3 (each within the scatter of the next, the first and the last beyond it).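

In this assay, 2-methylphenyl on the saturated chain carbon bound to an amide-type nitrogen in a ring gives a 2.6-fold lower number from compound 3 to compound 4 (0.41 log units; beyond the scatter) and a 2.3-fold lower number from compound 2 to compound 4 (0.37 log units; beyond the scatter), so it stands modestly apart from both 4-phenylphenyl and 4-fluorophenyl. Against the 4-methylphenyl group the step is a 1.2-fold lower number from compound 1 to compound 4 (0.10 log units; within the scatter), so compound 1 and compound 4 cannot be ordered, and moving the methyl on this ring has no readable effect. Nothing available explains these differences in the cell read-out.

The compounds shown leave open whether an amine or a carboxylic acid on this aromatic ring, or a longer chain linking the ring to the amide-type nitrogen, would shift the number further. They also leave open how changes elsewhere would behave, as all four compounds keep the rest of the structure unchanged.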